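Branching the side chain on the glucagon receptor core

A few compounds are considered here, and "the series" means these few. Any claim that something is new, unique, unknown or untested is made for them only; others in the source may bear on it.

Compound 2, `CCCCC[C@H](c1ccc(C(=O)NCc2nn[nH]n2)cc1)N1C(=O)C(c2cc(Cl)cc(Cl)c2)=N[C@]12CC[C@@H](C(C)(C)C)CC2`, has the lowest number among the two numbers shown so far in an assay on membranes from liver for displacement of a labelled ligand from Glucagon receptor (Mus musculus), read by scintillation counting, with a stated time of 60 min; a lower number here means a stronger inhibitor, a higher number a weaker inhibitor. In this assay compound 2 gives 310 nM. Compound 1, `CCC[C@H](c1ccc(C(=O)NCc2nn[nH]n2)cc1)N1C(=O)C(c2cc(Cl)cc(Cl)c2)=N[C@]12CC[C@@H](C(C)(C)C)CC2`, gives 500 nM in this assay, and the difference between them, a 1.6-fold lower number from compound 1 to compound 2 (0.21 log units; within the scatter), is an ethyl in place of hydrogen on a saturated chain carbon, four bonds along the chain from an amide-type nitrogen in a ring and an aromatic carbon. Compound 3, `C[C@H](c1ccc(C(=O)NCCC(=O)O)cc1)N1C(=O)C(c2ccccc2F)=N[C@]12CC[C@@H](C(C)(C)C)CC2`, differs from both in several places at once. For compound 3 this assay reports only a limit, > 10000 nM, not a number; it sits at the edge described by the limit of > 10000 nM in this assay, at which 1 of the 3 values shown sits.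

Compound 4, `CC1(CC[C@H](c2ccc(C(=O)NCc3nn[nH]n3)cc2)N2C(=O)C(c3cc(Cl)cc(Cl)c3)=N[C@]23CC[C@@H](C(C)(C)C)CC3)CC1`, is not yet measured. It carries 1-methylcyclopropyl in place of propyl on a saturated chain carbon, three bonds along the chain from an amide-type nitrogen in a ring and an aromatic carbon. Among the measured compounds shown here, the only single-point step at hand is the chain lengthening from compound 1 to compound 2, which stayed within the scatter, so adding a ring-closed branch to the same chain is expected to shift the number little. The expected step from compound 2 to compound 4 is a 1.0-fold lower number from compound 2 to compound 4 (0.01 log units; within the scatter). Compound 4 is therefore estimated at 300 nM, within a range from 120 nM to 800 nM.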

Compound 4, half-maximal inhibitory concentration: 110 nM
Beside the measured number, compound 4's estimate is 2.7-fold (0.44 log units) above it; measured number below the stated range.
By their numbers in this assay, from the lowest: compound 4; then compounds 2 and 1 (each within the scatter of the next). At a limit, above all of these: compound 3.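

In this assay, the earlier change on this chain, a 1.6-fold lower number from compound 1 to compound 2 (0.21 log units; within the scatter), did not separate the two compounds. Replacing propyl with 1-methylcyclopropyl on the same saturated chain carbon does separate them, giving a 2.8-fold lower number from compound 2 to compound 4 (0.45 log units; beyond the scatter) and, against the shorter-chained compound, a 4.5-fold lower number from compound 1 to compound 4 (0.66 log units; beyond the scatter), so this position does respond to the group placed there, and compound 4 has the lowest number of those measured at 110 nM. No measurement shown here explains why this group gives a lower number than the open chains.

The 1-methylcyclopropyl group brings its ring and its methyl together, so these compounds cannot say whether the ring, the methyl or the branching accounts for the step, and a plain cyclopropyl or a tert-butyl group at this position would help to separate them. As far as these compounds go, it also remains open whether the chain tolerates an atom other than carbon, such as an amine or a hydroxyl group, and whether the gain carries over to other versions of the shared core.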